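The source may report more compounds than this note shows. Statements on the series, on what has been measured and on what is new or still open speak of the compounds shown alone.

Measured in an ADME assay (liver) for metabolic stability, with Liver microsome (Homo sapiens) as the target, using microsomes; a higher number here means that the compound lasts longer, a lower number that the compound disappears faster:

compound 1 `CCc1nc2cc(Cl)ccn2c1C(=O)NCc1ccc(N2CCCCC2)cc1`: 0.22 h
compound 2 `CCc1nc2cc(Cl)ccn2c1C(=O)NCc1ccc(N2CCC(Cl)CC2)cc1`: 0.183 h
compound 3 `CCc1nc2cc(Cl)ccn2c1C(=O)NCc1ccc(N2CCC(c3ccc(F)cc3)CC2)cc1`: 0.113 h

In this assay, compound 3 stands at 0.113 h, within the scatter of both other compounds. Compound 4 `CCc1nc2cc(Cl)ccn2c1C(=O)NCc1ccc(N2CCC(c3ccc(Cl)cc3)CC2)cc1` differs from compound 3 by one exchange: chloro in place of fluoro on an aromatic carbon. In words, this is chloro in place of fluoro on an aromatic carbon.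

Among the compounds with values here, no measured step covers this exchange, since all three changes fall on a saturated ring carbon. They are a 1.2-fold lower number from compound 1 to compound 2 (0.08 log units; within the scatter), a 1.9-fold lower number from compound 1 to compound 3 (0.29 log units; within the scatter) and a 1.6-fold lower number from compound 2 to compound 3 (0.21 log units; within the scatter). Each stays within the scatter, including the exchange of chloro for 4-fluorophenyl, so the series offers only indirect guidance. Because the largest of these, a 1.9-fold lower number from compound 1 to compound 3 (0.29 log units; within the scatter), is still this small, no step beyond the scatter is expected in this assay, and no direction can be favoured with confidence. The expected outcome is a 1.1-fold lower number from compound 3 to compound 4 (0.03 log units; within the scatter). For compound 4 the estimated half-life is 0.105 h, with an expected range from 0.06 h to 0.18 h.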

Compound 4, half-life: 1.12 h
For compound 4 the middle estimate is 11-fold (1.03 log units) below the measured one; the measured number lies above the stated range.
By their numbers in this assay, from the lowest: compounds 3, 2 and 1 (each within the scatter of the next); then compound 4.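

In this assay the aromatic carbon of the 4-fluorophenyl group proves to be a sensitive position: chloro in place of fluoro there gives the largest step in the series (a 9.9-fold higher number from compound 3 to compound 4 (1.00 log units; beyond the scatter)), while all earlier changes, made on the saturated ring carbon, stayed within the scatter. The 4-chlorophenyl group also separates from the smaller substituents on that saturated ring carbon (a 6.1-fold higher number from compound 2 to compound 4 (0.79 log units; beyond the scatter); a 5.1-fold higher number from compound 1 to compound 4 (0.71 log units; beyond the scatter)), something 4-fluorophenyl did not do. Nothing available here explains this longer half-life.

The compounds shown leave open whether the step is particular to chloro, since bromo, methyl or a nitrile on the same aromatic carbon would test this. They also leave open whether the same exchange of fluoro for chloro would have a comparable effect with a different group in place of the shared core.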